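Swapping pyridin-3-yl for pyridin-4-yl

The source may hold more compounds than are shown below. What is called first, only, known or untested is meant among the compounds shown, and "the series" means these compounds.

For the measured compounds named here, only two compounds have numbers so far. In a functional assay on HL-60 cells (Homo sapiens) for cytotoxicity, read by luminescence and CellTiter-Glo, with a stated time of 3 days (on this read-out higher numbers stand for weaker inhibition and lower numbers for stronger inhibition), compound 1 `N#Cc1ccc(NC(=O)c2ccc(Br)cc2O)cc1Cl` gives 440 nM while compound 2 `N#Cc1ccc(NC(=O)c2ccc(-c3cccnc3)cc2O)cc1` gives 6660 nM as the higher of the two numbers. Compound 2 is therefore the weaker inhibitor of the pair, and the gap lies beyond the usual scatter.

Compound 3 `N#Cc1ccc(NC(=O)c2ccc(-c3ccncc3)cc2O)cc1` has pyridin-4-yl in place of pyridin-3-yl on an aromatic carbon and so holds the same atoms as compound 2, joined differently. Going by the values given here, no measured pair shows this kind of swap, so the expectation rests on compound 2 at 6660 nM as its closest measured neighbour. The expected step is a 1.3-fold lower number from compound 2 to compound 3 (0.12 log units; within the scatter) and it stays within the scatter, with no firm direction. Compound 3 is estimated at 5000 nM with a likely range from 1800 nM to 14000 nM in this assay once measured.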

Compound 3, half-maximal inhibitory concentration: 7090 nM
Estimate against measurement, compound 3: 1.4-fold (0.15 log units) below; low and high end bracket the measured number.
By their numbers in this assay, from the lowest: compound 1; then compounds 2 and 3 (each within the scatter of the next).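

Exchanging pyridin-3-yl for pyridin-4-yl, on an aromatic carbon para to a large group, gives a 1.1-fold higher number from compound 2 to compound 3 (0.03 log units; within the scatter) in this assay. This is the first pair shown that differs in one place, and it shows that the two pyridine isomers cannot be told apart in this read-out when attached to this core. No measurement shown here offers an explanation for this result.

Going by these compounds, whether pyridin-2-yl, a plain phenyl ring or a morpholine group at the same position would move the number beyond the scatter remains open. Compound 1 differs from compound 2 in more than one place, so its lower number cannot be assigned to any single group, including the bromine.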